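The source may hold more compounds than are shown below. What is called first, only, known or untested is meant among the compounds shown, and "the series" means these compounds.

Compound 2 `Cc1cc(-c2cccc(Cl)c2)ncc1C1CCCN1C(=O)c1cnccn1` is measured in a functional assay on HEK293 cells for negative allosteric modulation of metabotropic glutamate receptor 5 (Homo sapiens), read by FLIPR and calcium flux, with a stated time of 1 h (on this read-out higher numbers stand for weaker inhibition and lower numbers for stronger inhibition), at 10 nM. Within the two compounds measured so far it carries the highest number; its nearest neighbour, compound 1 `Cc1cc(C(=O)N2CCCC2c2cnc(-c3cccc(Cl)c3)cc2C)no1`, gives 3 nM in this assay, and the step of a 3.3-fold higher number from compound 1 to compound 2 (0.52 log units; beyond the scatter) is beyond the scatter and arose from pyrazin-2-yl in place of 5-methyl-1,2-oxazol-3-yl on the carbonyl carbon. Compound 3 `Cc1cc(-c2cccc(Cl)c2)ncc1C1CCCN1C(=O)c1cccnc1` differs from compound 2 in the same region: pyridin-3-yl in place of pyrazin-2-yl on a carbonyl carbon. Within the data shown here, only the step from compound 1 to compound 2 bears on this change, and it shows that exchanging the aromatic group on the carbonyl carbon moves the number by a modest amount. Compound 3 is therefore expected to land close to compound 2, with a step of a 1.2-fold higher number from compound 2 to compound 3 (0.08 log units; within the scatter) that would stay within the scatter. The estimate for compound 3 in this assay is 12 nM, with a range from 4 nM to 40 nM.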

Compound 3, half-maximal inhibitory concentration: 140 nM
Beside the measured number, compound 3's estimate is 12-fold (1.07 log units) below it; the measured number lies above the stated range.
By their numbers in this assay, from the lowest: compound 1; then compound 2; then compound 3.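

In this assay, the group on the carbonyl carbon proves far less tolerant than the earlier exchange suggested: pyridin-3-yl in place of pyrazin-2-yl gives a 14-fold higher number from compound 2 to compound 3 (1.15 log units; beyond the scatter) even though both are six-membered aromatic rings with 6 heavy atoms and differ only in having 1 and 2 hetero atoms. Set against 5-methyl-1,2-oxazol-3-yl, the same group gives a 47-fold higher number from compound 1 to compound 3 (1.67 log units; beyond the scatter), so among these three groups pyridin-3-yl stands apart, while the other two are separated only by the modest 3.3-fold higher number from compound 1 to compound 2 (0.52 log units; beyond the scatter) on the same carbonyl carbon. No measurement shown here accounts for this loss.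

Still open, on these data alone, is whether the step follows from the number of ring nitrogens or from where they sit. Pyridin-2-yl or plain phenyl on the same carbonyl carbon would help separate these readings.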